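From butoxy to a (3-carboxypropyl)amino side chain

The source may hold more compounds than are shown below. What is called first, only, known or untested is meant among the compounds shown, and "the series" means these compounds.

In an ADME assay on the whole organism (serum) with Homo sapiens as the target (on this read-out lower numbers stand for a shorter-lived compound and higher numbers for a longer-lived compound), compound 3 `CCCCOC(=O)OCC1OC(n2cc(C)c(=O)[nH]c2=O)CC1N=[N+]=[N-]` gives 0.15 h, the lower of the two numbers measured, while compound 2 `Cc1cn(C2CC(N=[N+]=[N-])C(COC(=O)OCCCCO)O2)c(=O)[nH]c1=O` gives 0.5 h. Compound 4 `Cc1cn(C2CC(N=[N+]=[N-])C(COC(=O)NCCCC(=O)O)O2)c(=O)[nH]c1=O` carries (3-carboxypropyl)amino in place of butoxy on a carbonyl carbon. Among the compounds with values here, the only measured step, a 3.3-fold lower number from compound 2 to compound 3 (0.52 log units; beyond the scatter), is modest and concerns hydrogen in place of hydroxy, so it offers little guidance on this change. Compound 1 `Cc1cn(C2CC(N=[N+]=[N-])C(COC(=O)NCCCC(=O)OC(C)(C)C)O2)c(=O)[nH]c1=O` bears more directly: it also has an amino group on that carbonyl carbon, and its > 48 h is a limit, not a number. On that basis, a large upward step is expected in this assay, estimated as a 200-fold higher number from compound 3 to compound 4 (2.30 log units; beyond the scatter). For compound 4 the estimated half-life is 30 h, within a wide range of 5 h to 120 h.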

Compound 4, half-life in the Homo sapiens assay: > 48 h
Compound 4: a limit, no number; the forecaster's own chance of this, stated with the estimate: 45%; middle value at least 1.6-fold (0.20 log units) away from the limit.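

In the Homo sapiens assay, (3-carboxypropyl)amino in place of butoxy on a carbonyl carbon gives an at least 320-fold higher number from compound 3 to compound 4 (2.50 log units; beyond the scatter), and in place of 4-hydroxybutoxy it gives an at least 96-fold higher number from compound 2 to compound 4 (1.98 log units; beyond the scatter). In a physicochemical assay for lipophilicity (a lower number here means a more polar compound, a higher number a more lipophilic compound), compound 3 gives 1.02 and compound 4 gives -0.81. This large rise in half-life comes with a more polar compound in the physicochemical assay: the measured partition coefficient of compound 3, 1.02, and of compound 4, -0.81, a number 1.83 log units lower (beyond the scatter) Hydrogen in place of tert-butyl leaves a step that cannot be read, because compound 1 and compound 4 both sit at a limit: the limit of > 48 h in the Homo sapiens assay, at which 2 of the 4 values shown sit.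

Going by these compounds, whether the gain follows the amino nitrogen or the carboxylic acid stays open. A butylamino group on that carbonyl carbon would separate the two.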